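A few compounds are considered here, and "the series" means these few. Any claim that something is new, unique, unknown or untested is made for them only; others in the source may bear on it.

Measured compounds:
compound 1, `C=CCc1cc(C(C)=O)c(O)cc1OCCCCCCC#N`, 63%;
compound 2, `CCc1cc(C(C)=O)c(O)cc1OCCCCC(C)(C)C#N`, 30%.

In an assay on isolated protein for binding affinity to leukotriene B4 receptor 1 (Homo sapiens), tested at 1 uM (on this read-out lower numbers stand for less inhibition and higher numbers for more inhibition at the one concentration tested (going by the name of the read-out)), compound 1 gives 63% and compound 2 gives 30%. Compound 2 thus holds the lower of the two values, and its gap to compound 1 lies beyond the usual scatter; the two compounds differ in more than one place, so only the two values themselves are known here, not a single-point step.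

Compound 3, `CCc1cc(C(C)=O)c(O)cc1OCCCCCCS(C)(=O)=O`, has not yet been measured. It differs from compound 2 in one place: 2-(methylsulfonyl)ethyl in place of 1-cyano-1-methylethyl on a saturated chain carbon, four bonds along the chain from an oxygen on an aromatic ring. Among the compounds with values here, no measured pair shows this change, so the direction can only be guessed. The one other chain ending in view, that of compound 1, sits higher in this assay, but it carries a second change as well. The step from compound 2 to compound 3 in this assay is expected to be a number 8 percentage points higher from compound 2 to compound 3 (within the scatter), possibly not beyond the scatter. Compound 3 is estimated at 38%, with a range from 12% to 62%.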

Compound 3, a percentage reported as inhibition, at one concentration (the size of the read-out at that concentration, not a potency): 62%
The estimate for compound 3 lay 24 percentage points below the measured number; the measured number falls inside the stated range.
By their numbers in this assay, from the lowest: compound 2; then compounds 3 and 1 (each within the scatter of the next).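

In this assay, the group at this place on the chain turns out to matter on the otherwise unchanged shared core: 2-(methylsulfonyl)ethyl in place of 1-cyano-1-methylethyl gives a number 32 percentage points higher from compound 2 to compound 3 (beyond the scatter) and is a large step. The earlier pair could not show this, since its two compounds differ in more than one place, whereas this step isolates the group on the saturated chain carbon, four bonds along the chain from an oxygen on an aromatic ring. Nothing measured here accounts for the size of the step.

The compounds shown leave open whether the step follows from the sulfonyl group entering, from the nitrile leaving, or from the loss of the branching in 1-cyano-1-methylethyl. They also leave open how a sulfonamide, a carboxylic acid or a longer chain ending in methylsulfonyl would compare with compound 3 at 62% in this read-out.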